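The compounds below may be only part of what the source reports. "The series", "measured", "known", "first", "only" and "open" are said of these compounds alone.

Of the compounds shown here, three built on one shared core have been measured in an assay on CHO cells for antagonist activity at transient receptor potential cation channel subfamily V member 1 (Homo sapiens), read by scintillation counting, with a stated time of 5 min, in the presence of a further agent that is not named here; a higher number here means that more compound is needed for the effect, a lower number that less compound is needed. Compound 1 `CN(C)C1(Cc2ccccc2)CCN(c2cc(C(F)(F)F)ccc2CNC(=O)NCc2ccc(NS(C)(=O)=O)c(F)c2)CC1` gives 85.9 nM in this assay, and compound 2 `CN(C)C1(Cc2ccccc2)CCN(c2cc(C(F)(F)F)ccc2CNC(=O)Nc2ccc(CNS(N)(=O)=O)c(F)c2)CC1` gives 120 nM. Compound 3 `CN(C)C1(Cc2ccccc2)CCN(c2cc(C(F)(F)F)ccc2CNC(=O)Nc2cccc3ccc(O)cc23)CC1` gives 8.9 nM, the lowest of the three numbers; its gap to compound 1 and its gap to compound 2 both lie beyond the usual scatter, so compound 3 is the most potent of the measured set.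

Compound 4 `CN(C)C1(Cc2ccccc2)CCN(c2cc(C(F)(F)F)ccc2CNC(=O)Nc2ccc3c(c2)OCC3)CC1` has not yet been measured in this assay. It differs from compound 3 in one place: a group of 9 heavy atoms (8 carbon, 1 oxygen; one five-membered non-aromatic ring with 1 hetero atom, one six-membered aromatic ring of carbon only) in place of a group of 11 heavy atoms (10 carbon, 1 oxygen; 2 six-membered aromatic rings of carbon only), on an amide-type nitrogen. Among the measured compounds shown here, no pair of measured compounds differs only at this nitrogen, so the effect of this particular change cannot be read from the numbers already in hand; compounds 1 and 2 carry other groups there and differ from compound 3 at further places as well. For the measured compounds named here, since the group that leaves belongs to the compound with the lowest number so far, a moderate loss seems the more likely outcome, and compound 4 is expected to show a step of a 2.8-fold higher number from compound 3 to compound 4 (0.45 log units; beyond the scatter) in this assay. Compound 4 is estimated at 25 nM, with a range from 8 nM to 80 nM.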

Compound 4, half-maximal effective concentration: 31.3 nM
Compound 4: the middle estimate sits 1.3-fold (0.10 log units) below what was measured; the range from low to high includes it.
By their numbers in this assay, from the lowest: compound 3; then compound 4; then compounds 1 and 2 (each within the scatter of the next).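

Among the compounds shown here, at the amide-type nitrogen, compounds 3 and 4 form the first pair in this assay that differs in one place only, and replacing 7-hydroxynaphthalen-1-yl with the group carrying one five-membered non-aromatic ring and one six-membered aromatic ring of carbon only gives a 3.5-fold higher number from compound 3 to compound 4 (0.55 log units; beyond the scatter). The entering group has 0 hydrogen-bond donors where the leaving group has 1, yet compound 4 still gives 31.3 nM, so a hydrogen-bond donor in the group at this nitrogen is not required for activity in this series, though the number is higher without one. No independent measurement is available to show which difference between the two groups accounts for the step.

The ring systems and the hydroxyl group change together in this pair, so their separate contributions remain unresolved. As far as these compounds go, it remains open whether plain naphthalen-1-yl without the hydroxyl group would stay close to compound 3 or to compound 4, and whether a methoxy group or an amine in place of that hydroxyl group would be tolerated at this nitrogen's substituent.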